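A few compounds are considered here, and "the series" means these few. Any claim that something is new, unique, unknown or untested is made for them only; others in the source may bear on it.

Compound 1 `COc1cc(C(=O)N/N=C/c2ccc(F)c(F)c2)cc(OC)c1OC`: 51.9%
Compound 2 `COc1cc(C2=NN(C(C)=O)C(c3ccccc3C(F)(F)F)O2)cc(OC)c1OC`: 34.8%
Compound 3 `COc1cccc(/C=N/NC(=O)c2cc(OC)c(OC)c(OC)c2)c1OC`: 14.2%

Of the compounds shown here, three have been tested in a functional assay on BGC-823 cells (Homo sapiens) for antiproliferative activity, read by MTT assay, tested at 5 uM; on this read-out lower numbers stand for a weaker effect and higher numbers for a stronger effect at the one concentration tested. Compound 1 gives the highest number of the three; compound 2 comes nearest, and compound 3 lies furthest below, both gaps reaching beyond the usual scatter. Compound 4 `COc1cc(C(=O)N/N=C/c2ccccc2F)cc(OC)c1OC` has not yet been tested. It differs from compound 1 in one place: 2-fluorophenyl in place of 3,4-difluorophenyl on a carbon with a double bond to nitrogen. For the measured compounds named here, no two measured compounds differ in a single place, so no measured step of this kind is available, and the shared core of compound 1 offers the only anchor. In this assay the step is expected to be a modest drop, a number 11.9 percentage points lower from compound 1 to compound 4 (beyond the scatter), with wide uncertainty. Compound 4 is estimated at 40%, most likely between 15% and 62%.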

Compound 4, a percentage reported as inhibition, at one concentration (the size of the read-out at that concentration, not a potency): 76.5%
For compound 4 the middle estimate is 36.5 percentage points below the measured one; the measured number lies above the stated range.
By their numbers in this assay, from the lowest: compound 3; then compound 2; then compound 1; then compound 4.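

In this assay, the group on the carbon with a double bond to nitrogen clearly affects the result: putting 2-fluorophenyl in place of 3,4-difluorophenyl gives a number 24.6 percentage points higher from compound 1 to compound 4 (beyond the scatter). The ring stays the same and only its fluorine substitution changes, so this position responds to a small edit. No data shown explain this rise.

This single step cannot separate the effect of losing one fluorine from that of moving fluorine around the ring. From the compounds shown here alone, how an unsubstituted phenyl, a chlorophenyl or a pyridine ring would behave here remains open.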